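This account rests on a few compounds, and the source may have more. Where it says the series, first, only, none or still open, it means among the compounds named here.

Measured compounds:

Compound 1 `N#CC1=C(N)Oc2c(c3nc4ccccc4nc3c3ccccc23)C12C(=O)N(Cc1cnnn1-c1ccc(Cl)cc1)c1ccccc12` — in a functional assay on HCT-116 cells (Homo sapiens) for antiproliferative activity, read by MTT assay, with a stated time of 48 h (a lower number here means a stronger inhibitor, a higher number a weaker inhibitor), compound 1 gives > 50000 nM, which is a limit of the assay, not a number.
Compound 2 `N#CC1=C(N)Oc2c(c3nc4ccccc4nc3c3ccccc23)C12C(=O)N(Cc1cnnn1-c1ccc(Br)cc1)c1ccccc12` — in this assay compound 2 gives > 50000 nM, also a limit of the assay.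
Compound 3 `N#CC1=C(N)Oc2c(c3nc4ccccc4nc3c3ccccc23)C12C(=O)N(Cc1cnnn1-c1ccc(S(N)(=O)=O)cc1)c1ccccc12` — in this assay compound 3 gives 31200 nM.

Compound 1 therefore stands only at a limit, and the limit of > 50000 nM in this assay, at which 2 of the 3 values shown sit, marks where most of these values sit. The change to compound 4 `N#CC1=C(N)Oc2c(c3nc4ccccc4nc3c3ccccc23)C12C(=O)N(Cc1cnnn1-c1cccc(S(N)(=O)=O)c1)c1ccccc12` is 3-sulfamoylphenyl in place of 4-chlorophenyl on an aromatic nitrogen. The nearest measured step is an at least 1.6-fold lower number from compound 1 to compound 3 (0.20 log units; that floor lies within the scatter), where the sulfamoyl group sits at the 4-position of the phenyl ring; a matching step is an at least 1.6-fold lower number from compound 2 to compound 3 (0.20 log units; that floor lies within the scatter). The step that the two limits leave unreadable from compound 1 to compound 2 cannot be read because both values are limits. Within the data shown here, compound 4 carries the sulfamoyl group at the 3-position instead, a change for which no measured pair exists, so the expected step is small and in the same direction, down to a number near compound 3. Compound 4 is expected to give 35000 nM, between 15000 nM and 90000 nM, which is an expected step of an at least 1.4-fold lower number from compound 1 to compound 4 (0.15 log units; that floor lies within the scatter).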

Compound 4, half-maximal inhibitory concentration: 11300 nM
Compound 4: middle estimate off by 3.1-fold (0.49 log units), on the high side; the whole stated range lies above it.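

Moving the sulfamoyl group on the phenyl ring changes the result in this assay: 3-sulfamoylphenyl in place of 4-sulfamoylphenyl gives a 2.8-fold lower number from compound 3 to compound 4 (0.44 log units; beyond the scatter), so the position of this group counts as well as its presence. Compared with the chloro and bromo compounds, the gap now clears the scatter, with an at least 4.4-fold lower number from compound 1 to compound 4 (0.64 log units; beyond the scatter) and an at least 4.4-fold lower number from compound 2 to compound 4 (0.64 log units; beyond the scatter). These two steps are only floors, since compound 1 and compound 2 each stand at a limit of the assay: the limit of > 50000 nM in this assay, at which 2 of the 4 values shown sit.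

The compounds shown leave open whether another group in the place of the sulfamoyl group in compound 4, such as an amine or a carboxylic acid, would give a lower number still. They also leave open whether a chloro or bromo group at that same place would do as well as the sulfamoyl group.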